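The source may report more compounds than this note shows. Statements on the series, on what has been measured and on what is new or still open speak of the compounds shown alone.

Compound 1 `O=C(/C=C\Nc1ccc2cc[nH]c2c1)c1nc(-c2ccc(C(F)(F)F)cc2)n2ccccc12` was examined in a functional assay on MDA-MB-231 cells (Homo sapiens) for cytotoxicity, read by MTT assay, with a stated time of 48 h; on this read-out higher numbers stand for weaker inhibition and lower numbers for stronger inhibition. In this assay compound 1 gives only a limit of the measurement, > 30000 nM, not a number. Compound 2 `COc1ccc(N/C=C\C(=O)c2nc(-c3ccc(F)cc3)n3ccccc23)cc1` likewise gives only a limit in this assay, > 30000 nM. Within the data shown here, both results sit at the limit of > 30000 nM in this assay, at which 2 of the 2 values shown sit, and no measured step between compounds exists here. Compound 3 `O=C(/C=C\Nc1ccc(Cl)cc1)c1nc(-c2ccc(C(F)(F)F)cc2)n2ccccc12` differs from compound 1 by 4-chlorophenyl in place of 1H-indol-6-yl on an amine nitrogen. Compound 3 is expected to remain near that limit, at 30000 nM with a range from 10000 nM to 100000 nM. The expected step of a number no higher from compound 1 to compound 3 (the limit leaves the size open) is none beyond the usual scatter.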

Compound 3, half-maximal inhibitory concentration: 3840 nM
Compound 3: middle estimate off by 7.8-fold (0.89 log units), on the high side, outside the stated range (below it).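

Replacing 1H-indol-6-yl with 4-chlorophenyl on the amine nitrogen, with the rest of the molecule unchanged, gives an at least 7.8-fold lower number from compound 1 to compound 3 (0.89 log units; beyond the scatter) in this assay. As far as these compounds go, the group on this nitrogen can therefore shift the read-out, but the full size of the step is unknown, since compound 1 gives only a limit. Compound 3 is the only compound here with a measured number rather than a limit: the limit of > 30000 nM in this assay, at which 2 of the 3 values shown sit.

The compounds shown do not separate the role of the chlorine from that of losing the five-membered ring. A plain phenyl or a 4-bromophenyl on this nitrogen would help to tell them apart.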